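Working notes: from compound 2 to compound 4

The compounds below may be only part of what the source reports. "The series", "measured", "known", "first", "only" and "open" are said of these compounds alone.

In an ADME assay on a cell-free system (plasma, Mus musculus) for metabolic stability, read by LC-MS, tested at 2 uM (on this read-out lower numbers stand for a shorter-lived compound and higher numbers for a longer-lived compound), compound 2 `CN1CCN(c2ccc3c(c2)oc(=O)n3C(=O)NCCCCc2ccccc2)C(=O)C1` gives 0.333 h. It stands level with compound 1 `CN1CCC(c2ccc3c(c2)oc(=O)n3C(=O)NCCCCc2ccc(F)cc2)CC1` at 0.333 h and compound 3 `CN1CCC(c2cc3oc(=O)n(C(=O)NCCCCc4ccccc4)c3cc2F)CC1` at 0.333 h, so the three measured compounds show no separation at the digits available.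

Compound 4 `CCN1CCC(c2ccc3c(c2)oc(=O)n3C(=O)NCCCCc2ccccc2)CC1` has not yet been measured. It departs from compound 2 at one place, on an aromatic carbon: 1-ethylpiperidin-4-yl in place of 4-methyl-2-oxopiperazin-1-yl on an aromatic carbon. In short, 1-ethylpiperidin-4-yl stands in place of 4-methyl-2-oxopiperazin-1-yl.

For the measured compounds named here, no measured pair differs in a single place, so the size of this change has no direct precedent. The nearest guide is indirect: compound 1 at 0.333 h and compound 2 at 0.333 h carry different groups at this place, yet read the same. The estimated step, a 1.0-fold lower number from compound 2 to compound 4 (0.00 log units; within the scatter), is therefore expected to stay within the scatter in this assay, with no direction favoured. For compound 4 the expected value is 0.33 h, with an estimated range of 0.2 h to 0.6 h.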

Compound 4, half-life: 0.833 h
Compound 4: the middle estimate sits 2.5-fold (0.40 log units) below what was measured; measured number outside the range, above it.
By their numbers in this assay, from the lowest: compounds 1, 2 and 3 (each within the scatter of the next); then compound 4.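

Working notes, continued: In this assay, the group on this aromatic carbon, meta and para to a fused ring, can shift the read-out: a 2.5-fold higher number from compound 2 to compound 4 (0.40 log units; beyond the scatter), the first single-place step in the series and one beyond the scatter. With 8 heavy atoms in both groups, the change is not one of heavy-atom count; 1-ethylpiperidin-4-yl has one hetero atom in its ring against two, no double bond outside aromatic rings, and one hydrogen-bond acceptor against two. Nothing available explains the higher number.

This single step changes several features at once, leaving the ring carbonyl, the second ring hetero atom and the ethyl group unseparated as contributors. Going by these compounds, how a morpholin-4-yl group or a primary amine would read at this place also remains open.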